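Difluoromethoxy Takes the Place of Methyl on the Core

The source may hold more compounds than are shown below. What is called first, only, known or untested is meant among the compounds shown, and "the series" means these compounds.

Compound 1, `COc1cc(C)c(Nc2nc(Cl)cn([C@H](C)C3CC3)c2=O)c(C)n1`: in an assay on frontal cortex for displacement of a labelled ligand from corticotropin-releasing factor receptor 1 (Rattus norvegicus) (a lower number here means a stronger inhibitor, a higher number a weaker inhibitor), compound 1 gives 12 nM.
Compound 2, `Cc1cc(C)c(Nc2nc(Cl)cn([C@H](C)C3CC3)c2=O)c(C)n1`: in this assay compound 2 gives 65 nM.

For the measured compounds named here, compound 2 holds the highest of the two numbers measured so far; its only neighbour is compound 1, and the one measured step between them is a 5.4-fold higher number from compound 1 to compound 2 (0.73 log units; beyond the scatter), a change of methyl in place of methoxy on an aromatic carbon. Going by the values given here, that step is modest but beyond the scatter, and it is the only piece of evidence bearing on the next change.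

Compound 3, `Cc1cc(OC(F)F)nc(C)c1Nc1nc(Cl)cn([C@H](C)C2CC2)c1=O`, differs from compound 2 by difluoromethoxy in place of methyl on an aromatic carbon. One hydrogen-bond acceptor enters where none left. The step that matters here is the reverse direction of a 5.4-fold higher number from compound 1 to compound 2 (0.73 log units; beyond the scatter), since an oxygen-linked group returns to the same aromatic carbon. Compound 3 is therefore expected to come in lower than compound 2, at about 22 nM in this assay, within 7 nM to 70 nM. That estimate means a 3.0-fold lower number from compound 2 to compound 3 (0.47 log units; beyond the scatter), expected to be beyond the scatter, though not necessarily recovering the full distance back to compound 1.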

Compound 3, half-maximal inhibitory concentration in the corticotropin-releasing factor receptor 1 assay: 2.1 nM
Beside the measured number, compound 3's estimate is 10-fold (1.02 log units) above it, outside the stated range (below it).
By their numbers in the corticotropin-releasing factor receptor 1 assay, from the lowest: compound 3; then compound 1; then compound 2.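

Difluoromethoxy on this aromatic carbon, next to the ring nitrogen, does more in the corticotropin-releasing factor receptor 1 assay than undo the loss seen with methyl, giving a 31-fold lower number from compound 2 to compound 3 (1.49 log units; beyond the scatter). The oxygen alone does not account for this result, as difluoromethyl in place of methyl on that oxygen gives a 5.7-fold lower number from compound 1 to compound 3 (0.76 log units; beyond the scatter). The same change from methyl to difluoromethoxy also moves a second measured quantity, with the proton given up far more readily in a physicochemical assay for acid dissociation, read by spectrophotometry, at pH 2: the measured acid dissociation constant of compound 2, 7.9, and of compound 3, < 2, a number at least 5.90 log units lower (beyond the scatter)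

In the physicochemical assay compound 2 gives 7.9. In the physicochemical assay compound 3 gives < 2, which is a limit of the assay and not a number, and the compounds shown do not tell whether this shift has anything to do with the lower number in the corticotropin-releasing factor receptor 1 assay. Also open, from the compounds shown here alone, is how a trifluoromethoxy group or an amine on the same aromatic carbon would read in the corticotropin-releasing factor receptor 1 assay, and whether the gain would hold with a group other than chlorine on the shared core.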